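This account rests on a few compounds, and the source may have more. Where it says the series, first, only, none or still open, it means among the compounds named here.

Of the compounds shown here, two of a shared core have been measured in an assay on SH-SY5Y cells for inhibition of Voltage-dependent N-type calcium channel subunit alpha-1B (Homo sapiens), read by FLIPR and calcium flux, with stated times of 600 s and 300 s, in the presence of a further agent that is not named here; a lower number here means a stronger inhibitor, a higher number a weaker inhibitor. Compound 1, `N=C(N)NCCCOc1ccc(CNc2nc3ccc(Oc4cccc(C(F)(F)F)c4)cc3s2)cc1`, gives 130000 nM in this assay. Compound 2, `CN(Cc1ccc(OCCCNC(=N)N)cc1)c1nc2ccc(Oc3ccc(F)cc3)cc2s1`, gives 100000 nM in this assay. These two numbers lie within the scatter of each other, so neither compound can be called the stronger inhibitor on this evidence; both are weak, and compound 2 simply stands at one of two very similar values.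

Compound 3, `N=C(N)NCCCOc1ccc(CNc2nc3ccc(Oc4ccc(F)cc4)cc3s2)cc1`, has not yet been measured in this assay. It differs from compound 2 in a single place: hydrogen in place of methyl on a nitrogen on an aromatic ring. Going by the values given here, no pair of measured compounds shows the effect of this change on its own, so there is no measured step to lean on. Both measured compounds sit at the weak end of this assay, and a change this small is expected to leave compound 3 near them. The step of a 1.1-fold higher number from compound 2 to compound 3 (0.04 log units; within the scatter) is expected to stay within the scatter, in no clear direction. Compound 3 is therefore estimated at 110000 nM in this assay, with a range from 40000 nM to 300000 nM.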

Compound 3, half-maximal inhibitory concentration: 244000 nM
Compound 3: the middle estimate sits 2.2-fold (0.35 log units) below what was measured; measured number inside the range.
By their numbers in this assay, from the lowest: compounds 2, 1 and 3 (each within the scatter of the next, the first and the last beyond it).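

In this assay, putting hydrogen in place of methyl on the nitrogen on an aromatic ring gives a 2.4-fold higher number from compound 2 to compound 3 (0.39 log units; beyond the scatter) and so moves toward a weaker inhibitor; this step is modest but lies beyond the usual scatter, and it is the one direct reading of this change among the compounds shown. The other new step, 4-fluorophenyl in place of 3-(trifluoromethyl)phenyl on an oxygen on an aromatic ring, gives a 1.9-fold higher number from compound 1 to compound 3 (0.27 log units; within the scatter) and stays within the scatter, so with hydrogen on the nitrogen, this pair shows no clear effect of that swap. Nothing at hand accounts for the difference between the methyl and hydrogen compounds.

The compounds shown leave open whether methyl on that nitrogen gives a similar step when 3-(trifluoromethyl)phenyl sits on the oxygen, since this reading rests on a single pair carrying 4-fluorophenyl. They also leave open whether an ethyl group or a longer carbon chain on the same nitrogen would extend the step or reverse it, and whether either would bring a compound far from the weak end of this assay.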